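A few compounds are considered here, and "the series" means these few. Any claim that something is new, unique, unknown or untested is made for them only; others in the source may bear on it.

Working notes on the series. Compound 1 `O=c1cc(/C=C/C=C/c2ccc(O)c(O)c2)oc2ccccc12` is the parent; in a physicochemical assay for inhibition, read by fluorescence, with a stated time of 2 min (on this read-out higher numbers stand for weaker inhibition and lower numbers for stronger inhibition), compound 1 gives 330 nM. Compound 2 `O=c1cc(/C=C/C=C/c2ccc(O)c(O)c2)oc2cccc(O)c12` carries one added hydroxy on the core of compound 1; in this assay compound 2 gives 340 nM. The step of a 1.0-fold higher number from compound 1 to compound 2 (0.01 log units; within the scatter) shows that this hydroxy left the read-out where it was. Among the compounds with values here, on the numbers so far compound 1 sits at one of two values that lie within the scatter of each other, so nothing separates it from compound 2.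

Compound 3 `O=c1cc(/C=C/C=C/c2ccc(O)c(O)c2)oc2cc(O)ccc12` is not yet measured. It differs from compound 1 by hydroxy in place of hydrogen on an aromatic carbon. Within the data shown here, the only step that bears on this change is the other hydroxy addition to the same core, and that one stayed within the scatter. Because a 1.0-fold higher number from compound 1 to compound 2 (0.01 log units; within the scatter) stayed within the scatter, the expected step in this assay is no change at the digits printed from compound 1 to compound 3 (within the scatter), with no direction beyond the scatter. The estimated value for compound 3 is 330 nM, with a range from 170 nM to 650 nM.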

Compound 3, half-maximal inhibitory concentration: 290 nM
Estimate against measurement, compound 3: 1.1-fold (0.06 log units) above, within the range that was stated.
By their numbers in this assay, from the lowest: compounds 3, 1 and 2 (each within the scatter of the next).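

A second position on the core of compound 1 now shows the same result: in this assay, hydroxy in place of hydrogen on an aromatic carbon, meta to a fused ring and para to a fused ring, gives a 1.1-fold lower number from compound 1 to compound 3 (0.06 log units; within the scatter). Alongside a 1.0-fold higher number from compound 1 to compound 2 (0.01 log units; within the scatter), this makes two separate hydroxy additions to the shared core, and neither step goes beyond the scatter. Nothing available offers a reason for this result.

The compounds shown leave open whether a different group at this position, such as an amine, a carboxylic acid or a methoxy, would move the number beyond the scatter. They also leave open what two added hydroxy groups on the shared core would do together in one compound.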